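Removing the ring methyl on the way to compound 3

The source may report more compounds than this note shows. Statements on the series, on what has been measured and on what is new or still open speak of the compounds shown alone.

The account follows compound 1 `CN1CCCN(c2cncc(-c3cc(CCO)no3)c2)CC1` and the related compound 3 `OCCc1cc(-c2cncc(N3CCCNCC3)c2)on1`. For compound 1 the entry in an assay on SH-EP1 cells for agonist activity at Neuronal acetylcholine receptor; alpha4/beta2 (Homo sapiens), read by rubidium efflux, with a stated time of 9.5 min (a lower number here means a smaller maximal response, a higher number a larger maximal response), reads "not determined" (no result reported); it stands without a number there. A second measured compound, compound 2 `COCC[C@@H]1C[C@H]1c1cncc(N2CCCNCC2)c1`, shares the seven-membered non-aromatic ring with 2 nitrogen and carries it with hydrogen on the ring nitrogen; in this assay compound 2 gives 63%. Compound 3 arises from compound 1 by the change (hydrogen in place of methyl on an amine nitrogen in a ring). Among the compounds with values here, since compound 1 has no value, no step can be computed, and the expectation for compound 3 in this assay rests on compound 2 alone; a difference from that value beyond the usual scatter is not expected in either direction. Compound 3 is therefore estimated to give 60% in this assay, with a range from 35% to 90%.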

Compound 3, largest response reached (reported as efficacy), in percent of the reference or control that the assay uses: 58%
Beside the measured number, compound 3's estimate is 2 percentage points above it; low and high end bracket the measured number.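

In this assay, within the data shown here, compound 1 reads "not determined" (no result reported) and compound 3 gives 58% here, so no step between the two can be read. The compounds shown leave open what hydrogen in place of methyl on the ring nitrogen does to the maximal response. No supporting evidence bears on this result.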